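Swapping the naphthalenyl arm for a chlorophenyl on the shared core

The source may hold more compounds than are shown below. What is called first, only, known or untested is meant among the compounds shown, and "the series" means these compounds.

Measured compounds:
- compound 1 `Brc1cn2ccnc2c(-c2ccc3ncn(C4CCCCC4)c3c2)n1`: 26.3%
- compound 2 `c1ccc(-c2cn3ccnc3c(-c3ccc4ncn(C5CCCCC5)c4c3)n2)cc1`: 67.7%
- compound 3 `c1ccc2c(-c3cn4ccnc4c(-c4ccc5ncn(C6CCCCC6)c5c4)n3)cccc2c1`: 44.7%

In a functional assay on MOLT-4 cells (Homo sapiens) for inhibition, read by sulforhodamine B assay, with a stated time of 48 h, tested at 10 uM (a lower number here means less inhibition, a higher number more inhibition at the concentration tested (going by the name of the read-out)), compound 3 gives 44.7%, the second highest of the three numbers. Compound 1 sits lower, as a number 18.4 percentage points higher from compound 1 to compound 3 (beyond the scatter) shows, while compound 2 sits higher, as a number 23 percentage points lower from compound 2 to compound 3 (beyond the scatter) shows.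

Compound 4 `Clc1ccc(-c2cn3ccnc3c(-c3ccc4ncn(C5CCCCC5)c4c3)n2)cc1` has not yet been measured in this assay. It differs from compound 3 in one place: 4-chlorophenyl in place of naphthalen-1-yl on an aromatic carbon.

For the measured compounds named here, two measured steps bear on this change. Going from bromo to phenyl, a number 41.4 percentage points higher from compound 1 to compound 2 (beyond the scatter); going from phenyl to naphthalen-1-yl, a number 23 percentage points lower from compound 2 to compound 3 (beyond the scatter). The entering 4-chlorophenyl, like phenyl, is one six-membered aromatic ring of carbon only, and phenyl gave the highest number of the set in compound 2. The reverse of the phenyl-to-naphthalen-1-yl step therefore suggests a rise of modest size.

Compound 4 is expected to show a step of a number 15.3 percentage points higher from compound 3 to compound 4 (beyond the scatter) in this assay. The estimate for compound 4 is 60%, with a range from 40% to 78%.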

Compound 4, a percentage reported as inhibition, at one concentration (the size of the read-out at that concentration, not a potency): 8.87%
For compound 4 the middle estimate is 51.1 percentage points above the measured one; the measured number lies below the stated range.
By their numbers in this assay, from the lowest: compound 4; then compound 1; then compound 3; then compound 2.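

In this assay, adding a single chloro to the phenyl group of compound 2 gives a number 58.8 percentage points lower from compound 2 to compound 4 (beyond the scatter) and is the largest step seen at this position, so a small edit to the group can outweigh everything else measured here. Having one six-membered aromatic ring of carbon only is therefore not enough for a high number: 4-chlorophenyl has that ring, yet putting it in place of naphthalen-1-yl gives a number 35.8 percentage points lower from compound 3 to compound 4 (beyond the scatter) and putting it in place of bromo gives a number 17.4 percentage points lower from compound 1 to compound 4 (beyond the scatter) as well. The numbers also do not follow the size of the group, since phenyl and 4-chlorophenyl both have fewer heavy atoms than naphthalen-1-yl but fall on either side of it. Nothing available explains why the chloro lowers the number so sharply.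

As far as these compounds go, it remains open whether this drop is specific to chloro or would follow any group placed where chloro sits on the phenyl ring. A fluoro, a methoxy or an amine at that spot, or chloro moved elsewhere on the same ring, would separate these possibilities.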